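Quinoline Amides in a Pancreatic Cancer Cell Assay

A few compounds are considered here, and "the series" means these few. Any claim that something is new, unique, unknown or untested is made for them only; others in the source may bear on it.

Measured so far:
Compound 1, `Cc1cnc(C(=O)Nc2cc(Cl)cc3cccnc23)cn1`: 1500 nM
Compound 2, `COc1cc(NC(=O)c2cnc(C)cn2)c2ncccc2c1`: 270 nM
Compound 3, `O=C(Nc1cc(Cl)cc2cccnc12)c1ncccn1`: 800 nM

In a functional assay on MIA PaCa-2 cells (Homo sapiens) for inhibition, read by MTT assay, with a stated time of 72 h (a higher number here means a weaker inhibitor, a lower number a stronger inhibitor), compound 2 gives the lowest number of the three, and compound 3 stands between compound 1 and compound 2. The change from compound 1 to compound 2 is methoxy in place of chloro on an aromatic carbon, and it brought a 5.6-fold lower number from compound 1 to compound 2 (0.74 log units; beyond the scatter). Compound 1 and compound 3 differ in their cores by pyrimidin-2-yl in place of 5-methylpyrazin-2-yl on a carbonyl carbon, with a 1.9-fold lower number from compound 1 to compound 3 (0.27 log units; within the scatter). Compound 4, `COc1cc(NC(=O)c2ncccn2)c2ncccc2c1`, is not yet measured; it differs from compound 3 by methoxy in place of chloro on an aromatic carbon, the same kind of change as that from compound 1 to compound 2, though the surroundings are described once as meta to a group of 9 heavy atoms and once as meta to a large group. Because compound 1 to compound 2 gave a 5.6-fold lower number from compound 1 to compound 2 (0.74 log units; beyond the scatter), a step of similar size, a 5.3-fold lower number from compound 3 to compound 4 (0.73 log units; beyond the scatter), is expected from compound 3 to compound 4. Compound 4 is therefore estimated at 150 nM in this assay, likely between 60 nM and 400 nM.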

Compound 4, half-maximal inhibitory concentration: 1300 nM
For compound 4 the middle estimate is 8.7-fold (0.94 log units) below the measured one; measured number above the stated range.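

In this assay, methoxy in place of chloro does not carry over from one core to the other, since the step with the pyrimidin-2-yl amide, a 1.6-fold higher number from compound 3 to compound 4 (0.21 log units; within the scatter), does not match the earlier one: the same change on two cores in this assay, a 5.6-fold lower number (0.74 log units; beyond the scatter) from compound 1 to compound 2 and a 1.6-fold higher number (0.21 log units; within the scatter) from compound 3 to compound 4, 9.0-fold (0.96 log units) apart, beyond the scatter of two such steps

Pyrimidin-2-yl in place of 5-methylpyrazin-2-yl also differs between the two cores, now giving a 4.8-fold higher number from compound 2 to compound 4 (0.68 log units; beyond the scatter): the same change on two cores in this assay, a 1.9-fold lower number (0.27 log units; within the scatter) from compound 1 to compound 3 and a 4.8-fold higher number (0.68 log units; beyond the scatter) from compound 2 to compound 4, 9.0-fold (0.96 log units) apart, beyond the scatter of two such steps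

The two changes therefore do not add up across these four compounds, but a single pair for each change gives no reason for this and no rule for other cores.

The compounds shown leave open whether ethoxy or fluoro in place of chloro would follow compound 2 or compound 4. They also leave open how an amine on the carbonyl carbon would behave with either group on the ring.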